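Aryl swaps on the carbonyl carbon of the shared core

The source may hold more compounds than are shown below. What is called first, only, known or untested is meant among the compounds shown, and "the series" means these compounds.

Compound 1 `COc1cc(C(=O)C2Sc3nnc(-c4cc(OC)c(OC)c(OC)c4)n3NC2c2ccco2)cc(OC)c1OC` gives 48300 nM in a functional assay on A549 cells (Homo sapiens) for cytotoxicity, read by MTT assay, with a stated time of 48 h; a higher number here means a weaker inhibitor, a lower number a stronger inhibitor.
Compound 2 `COc1cc(-c2nnc3n2NC(c2ccco2)C(C(=O)c2ccc(C)cc2)S3)cc(OC)c1OC` returns only a limit in this assay, > 100000 nM.
Compound 3 `COc1cc(-c2nnc3n2NC(c2ccco2)C(C(=O)c2cccc(Br)c2)S3)cc(OC)c1OC` gives 36900 nM.

Compound 1 holds the highest outright number of the two measured; compound 3 stands within the scatter of it, a 1.3-fold lower number from compound 1 to compound 3 (0.12 log units; within the scatter). The third value is a limit (the limit of > 100000 nM in this assay, at which 1 of the 3 values shown sits).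

Compound 4 `COc1cc(-c2nnc3n2NC(c2ccco2)C(C(=O)c2ccco2)S3)cc(OC)c1OC` differs from compound 1 by furan-2-yl in place of 3,4,5-trimethoxyphenyl on a carbonyl carbon. The earlier swaps on the same carbonyl carbon bear on it: an at least 2.0-fold higher number from compound 1 to compound 2 (0.31 log units; beyond the scatter) and a 1.3-fold lower number from compound 1 to compound 3 (0.12 log units; within the scatter), with an at least 2.7-fold lower number from compound 2 to compound 3 (0.43 log units; beyond the scatter) between those two. Neither earlier swap introduced a five-membered ring, so the direction is uncertain; a step within the scatter or a modest rise is expected.

Compound 4 is expected near 60000 nM, between 20000 nM and 180000 nM. That estimate means a 1.2-fold higher number from compound 1 to compound 4 (0.09 log units; within the scatter).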

Compound 4, half-maximal inhibitory concentration: 68700 nM
The estimate for compound 4 lay 1.1-fold (0.06 log units) below the measured number; low and high end bracket the measured number.
By their numbers in this assay, from the lowest: compounds 3, 1 and 4 (each within the scatter of the next). At a limit, above all of these: compound 2.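

Furan-2-yl on the carbonyl carbon, a five-membered aromatic ring, stays within the scatter of both six-membered aryl groups with outright numbers (a 1.4-fold higher number from compound 1 to compound 4 (0.15 log units; within the scatter)) and (a 1.9-fold higher number from compound 3 to compound 4 (0.27 log units; within the scatter)), so shrinking the group this far leaves no readable change. The step from the other aryl group gives only a floor (an at least 1.4-fold lower number from compound 2 to compound 4 (0.16 log units; that floor lies within the scatter)). Compound 2 is a limit: the limit of > 100000 nM in this assay, at which 1 of the 4 values shown sits.

Still open, as far as these compounds go, is how an aryl ring carrying an amine or a carboxylic acid would read at this carbonyl carbon in this assay (no such group appears here). From the compounds shown here alone, whether thiophene would match furan-2-yl also remains open.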